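This account rests on a few compounds, and the source may have more. Where it says the series, first, only, none or still open, it means among the compounds named here.

Compound 1 `C=C[C@@](C)(/C=C/c1ccc(OC)cc1)CCC=C(C)C` is the starting point of this comparison. In a functional assay on Raji cells (Homo sapiens) for cytotoxicity, with a stated time of 72 h (on this read-out higher numbers stand for an effect only at larger amounts of compound and lower numbers for an effect already at smaller amounts), compound 1 gives > 26000 nM, which is a limit of the assay rather than a measured number. Compound 2 `C=C[C@@](C)(/C=C/c1ccc(O)cc1)CC/C=C/C#N` gives > 26000 nM in this assay, again a limit. Compound 3 `C=C[C@@](C)(/C=C/c1ccc(O)c(C=O)c1)CCC=C(C)C` gives > 26000 nM in this assay, also a limit. Every value shown here sits at the limit of > 26000 nM in this assay, at which 3 of the 3 values shown sit, so compound 1 cannot be placed above or below the other two on these numbers.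

Compound 4 `C=C[C@@](C)(/C=C/c1ccc(Nc2ccc(Cl)cc2)cc1)CCC=C(C)C` differs from compound 1 in one place: (4-chlorophenyl)amino in place of methoxy on an aromatic carbon. Among the measured compounds shown here, no step between two measured compounds is available to show what such a replacement does in this assay, since all three measured compounds reach only (the limit of > 26000 nM in this assay, at which 3 of the 3 values shown sit). The expected step in this assay is therefore cautious, an at least 1.3-fold lower number from compound 1 to compound 4 (0.11 log units; that floor lies within the scatter), and most likely no change beyond the scatter, with a limit again the most probable outcome. For compound 4 the estimate in this assay is 20000 nM, with a range from 5000 nM to 60000 nM.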

Compound 4, half-maximal effective concentration: > 26000 nM
Compound 4 ended at the assay's limit; the forecaster's own chance of this, stated with the estimate: 60%; middle value at least 1.3-fold (0.11 log units) from the limit.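

Compound 4 gives > 26000 nM in this assay, again a limit of the assay. No step from compound 1 to compound 4 can be read, since both compounds stop at the same limit: the limit of > 26000 nM in this assay, at which 4 of the 4 values shown sit.

The compounds shown leave open at what concentration, if any, each would affect these cells, and whether (4-chlorophenyl)amino in place of methoxy changes that concentration.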